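The source may report more compounds than this note shows. Statements on the series, on what has been measured and on what is new or still open speak of the compounds shown alone.

Compound 1 `CN(C)CCC(=O)Nc1cccc(-c2nc3ccccc3s2)c1` in an ADME assay for permeability, using PAMPA (a lower number here means that the compound crosses the layer more slowly, a higher number that the compound crosses the layer faster), gives 2080 10^-6 cm/s.
Compound 2 `O=C(Nc1cccc(-c2nc3ccccc3s2)c1)c1cnccc1Cl` in this assay gives 732 10^-6 cm/s.

Compound 2 holds the lowest of the two numbers. Among the measured compounds shown here, the single measured step, a 2.8-fold lower number from compound 1 to compound 2 (0.45 log units; beyond the scatter), swaps the entire group on the carbonyl carbon and so offers no direct guide to the present change. Compound 3 `O=C(Nc1cccc(-c2nc3ccccc3s2)c1)c1ccc(Cl)nc1Cl` differs from compound 2 by 2,6-dichloropyridin-3-yl in place of 4-chloropyridin-3-yl on a carbonyl carbon. For the measured compounds named here, with no measured step bearing on this change, only a small shift, if any, is expected: a 1.1-fold higher number from compound 2 to compound 3 (0.04 log units; within the scatter). Compound 3 is therefore estimated at 800 10^-6 cm/s, with a range from 350 10^-6 cm/s to 1800 10^-6 cm/s.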

Compound 3, apparent permeability: 104 10^-6 cm/s
For compound 3 the middle estimate is 7.7-fold (0.89 log units) above the measured one; measured number below the stated range.
By their numbers in this assay, from the lowest: compound 3; then compound 2; then compound 1.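

In this assay the group on the carbonyl carbon responds even to a change within the chloropyridines: 2,6-dichloropyridin-3-yl in place of 4-chloropyridin-3-yl gives a 7.0-fold lower number from compound 2 to compound 3 (0.85 log units; beyond the scatter) and so exceeds the scatter with the ring type kept. Among the compounds shown here, measured against the 2-(dimethylamino)ethyl group, the same 2,6-dichloropyridin-3-yl group gives a 20-fold lower number from compound 1 to compound 3 (1.30 log units; beyond the scatter) and is the largest step so far. Nothing measured here explains this drop.

As far as these compounds go, it remains open whether the second chlorine itself or the changed chlorine positions drive the step. From the compounds shown here alone, how 6-chloropyridin-3-yl or an amine on the pyridine would read also remains open.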